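The source may hold more compounds than are shown below. What is called first, only, known or untested is meant among the compounds shown, and "the series" means these compounds.

Measured so far:
- compound 1, `Cc1c(CCCC(=O)O)c2cccc(/C=C/c3ccc(OCCCCc4ccccc4)cc3)c2n1CC(=O)O`: in a functional assay on the whole organism for inhibition, with Cavia porcellus as the target, with stated times of 1 h and 10 min, at a dose of 1 mg/kg by the oral route (a lower number here means a weaker effect, a higher number a stronger effect of the compound at the dose given), compound 1 gives 33%
- compound 2, `Cc1c(F)cccc1CCCCOc1ccc(/C=C/c2cccc3c(CCCC(=O)O)c(C)n(CC(=O)O)c23)cc1`: in this assay compound 2 gives 94%

Compound 2 stands highest of the two numbers in this assay; its nearest neighbour is compound 1, and the step of a number 61 percentage points higher from compound 1 to compound 2 (beyond the scatter) lies beyond the scatter. That single step, in which 3-fluoro-2-methylphenyl replaced phenyl on a saturated chain carbon four bonds along the chain from an oxygen on an aromatic ring, is the only one on record, and it shows that a substituted phenyl at this place carries a much larger read-out than the bare ring.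

Compound 3, `Cc1c(CCCC(=O)O)c2cccc(/C=C/c3ccc(OCCCCc4c(F)ccc(F)c4F)cc3)c2n1CC(=O)O`, has not yet been measured. It differs from compound 2 as follows: 2,3,6-trifluorophenyl in place of 3-fluoro-2-methylphenyl on a saturated chain carbon, four bonds along the chain from an oxygen on an aromatic ring. Since a substituted phenyl at this position has given the high number of compound 2, and the new ring is again a substituted phenyl of the same size, compound 3 is expected to stay near the top of the range, with a step of a number 9 percentage points lower from compound 2 to compound 3 (within the scatter), small against the scatter. Compound 3 is therefore estimated at 85%, between 60% and 99%.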

Compound 3, a percentage reported as inhibition, in the whole organism at one dose (the size of the read-out at that dose, not a potency): 25%
For compound 3 the middle estimate is 60 percentage points above the measured one; measured number below the stated range.
By their numbers in this assay, from the lowest: compounds 3 and 1 (each within the scatter of the next); then compound 2.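

The position does not reward every substituted phenyl: in this assay, 2,3,6-trifluorophenyl in place of 3-fluoro-2-methylphenyl on the saturated chain carbon gives a number 69 percentage points lower from compound 2 to compound 3 (beyond the scatter), so the large read-out of compound 2 goes with that particular ring and not with substitution as such. Set against the bare ring, 2,3,6-trifluorophenyl in place of phenyl gives a number 8 percentage points lower from compound 1 to compound 3 (within the scatter), a step that stays inside the scatter, so in this assay the three fluorines leave the read-out indistinguishable from that of the unsubstituted ring, and only 3-fluoro-2-methylphenyl stands apart from the other two rings. No measurement is at hand that could account for the wide gap between the two substituted rings.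

Still open, on these data alone, is whether the methyl, the fluorine or the two together carry the high read-out of 3-fluoro-2-methylphenyl, which a 2-methylphenyl or a 3-fluorophenyl on the same chain would help to settle. Within the data shown here, also open is whether the advantage of that ring would survive on a shorter or longer chain than the one shared by these compounds.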